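One More Methyl on a Chain at the Assay Limit

The source may report more compounds than this note shows. Statements on the series, on what has been measured and on what is new or still open speak of the compounds shown alone.

In a functional assay on B16-F10 cells (Mus musculus) for antiproliferative activity, read by MTT assay, with a stated time of 72 h (a lower number here means a stronger inhibitor, a higher number a weaker inhibitor), compound 1 (`CCCCCCCCNC[C@@H]1OC[C@H](N)[C@@H]1O`) gives > 128000 nM as a limit of the assay and not as a number. Compound 2 (`CCCCCCCNC[C@@H]1OC[C@H](N)[C@@H]1O`) gives > 128000 nM as a limit. Compound 3 (`CCCCCCCCCNC[C@@H]1OC[C@H](N)[C@H]1O`) gives > 128000 nM as a limit too, so it has no number of its own, and the two further values are also limits. Compound 4 (`CCCCCCCCCCNC[C@@H]1OC[C@H](N)[C@H]1O`) departs from compound 3 by methyl in place of hydrogen on a saturated chain carbon, nine bonds along the chain from an amine nitrogen in one place: methyl in place of hydrogen on a saturated chain carbon, nine bonds along the chain from an amine nitrogen. Among the measured compounds shown here, the only measured step of this kind is a step that the two limits leave unreadable from compound 1 to compound 2 and it runs the other way, seven bonds along the chain. It offers no size to carry over. The whole record is the limit of > 128000 nM in this assay, at which 3 of the 3 values shown sit, and it favours no direction. In this assay no step beyond the scatter is therefore expected. The estimated step is an at least 1.0-fold lower number from compound 3 to compound 4 (0.02 log units; that floor lies within the scatter) and it may again prove unreadable. Compound 4 is expected at 120000 nM with 50000 nM to 260000 nM as the estimated range.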

Compound 4, half-maximal inhibitory concentration: > 128000 nM
Compound 4: a limit, no number (the forecaster's own chance of this, stated with the estimate: 60%); at least 1.0-fold (0.02 log units) between middle value and limit.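

In this assay compound 4 gives > 128000 nM, a limit and not a number, as compound 3 does, so no size can be read for the step between them. The compounds shown leave open whether any of these chains on the shared core gives a readable number: the limit of > 128000 nM in this assay, at which 4 of the 4 values shown sit.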